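This account rests on a few compounds, and the source may have more. Where it says the series, first, only, none or still open, it means among the compounds named here.

Working notes on the amide-linked series sharing one core. In an assay on isolated protein (Mus musculus) for inhibition of IL15-IL15 receptor (Homo sapiens), read by resazurin assay, with stated times of 30 min and 2.5 days (a lower number here means a stronger inhibitor, a higher number a weaker inhibitor), compound 1 `Cn1c(Cc2nn(C)c(=O)c3ccccc23)nnc1SCCCCCCCC(=O)Nc1ccc(I)cc1` gives 1300 nM, compound 2 `Cn1c(Cc2nn(C)c(=O)c3ccccc23)nnc1SCCCCCCCC(=O)Nc1ccc(Cl)cc1Cl` gives 1900 nM and compound 3 `CC(C)Oc1ccc(NC(=O)CCCCCCCSc2nnc(Cc3nn(C)c(=O)c4ccccc34)n2C)cc1` gives 1100 nM. Compound 3 has the lowest of the three numbers, yet its distance to compound 1 and to compound 2 stays within the scatter, so no order among them is claimed. The step to compound 4 `CN(C(=O)CCCCCCCSc1nnc(Cc2nn(C)c(=O)c3ccccc23)n1C)c1ccc(Cl)cc1Cl` is (2,4-dichlorophenyl)(methyl)amino in place of (4-isopropoxyphenyl)amino on a carbonyl carbon. Among the measured compounds shown here, the only measured step bearing on it, a 1.7-fold lower number from compound 2 to compound 3 (0.24 log units; within the scatter), swaps the same two aryl groups and stays within the scatter; the methyl on the amide nitrogen has no precedent here. Compound 4 is therefore expected to show a 1.8-fold higher number from compound 3 to compound 4 (0.26 log units; within the scatter), no step beyond the scatter, with an estimated 2000 nM in this assay, ranging from 800 nM to 5000 nM.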

Compound 4, half-maximal inhibitory concentration: 11900 nM
Compound 4: the middle estimate sits 6.0-fold (0.77 log units) below what was measured, outside the stated range (above it).
By their numbers in this assay, from the lowest: compounds 3, 1 and 2 (each within the scatter of the next); then compound 4.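

Methyl in place of hydrogen on the amide-type nitrogen, read in this assay, gives a step beyond the scatter (a 6.3-fold higher number from compound 2 to compound 4 (0.80 log units; beyond the scatter)), whereas the aryl swaps among compound 1, compound 2 and compound 3 all stayed within it. The two steps that change the aryl group as well (a 9.2-fold higher number from compound 1 to compound 4 (0.96 log units; beyond the scatter) and an 11-fold higher number from compound 3 to compound 4 (1.03 log units; beyond the scatter)) point the same way, but all three rest on compound 4 alone. Nothing available explains this loss.

On these data alone, whether methyl on the amide-type nitrogen of compound 3 gives a step of like size remains open. So does the outcome with ethyl on that nitrogen.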